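Adding a second hydroxy group to compound 2

A few compounds are considered here, and "the series" means these few. Any claim that something is new, unique, unknown or untested is made for them only; others in the source may bear on it.

In a functional assay on MCF7 cells (Homo sapiens) for cytotoxicity, read by MTT assay, with a stated time of 72 h (on this read-out lower numbers stand for stronger inhibition and higher numbers for weaker inhibition), compound 1 `COc1ccc(/C=C2\CCC/C(=C\c3ccc(OC)c(OC)c3)C2=O)cc1` gives 7800 nM. Compound 2 `COc1ccc(/C=C2\CCC/C(=C\c3ccc(O)cc3)C2=O)cc1OC` gives 17000 nM, the higher of the two numbers. Compound 3 `COc1ccc(/C=C2\CCC/C(=C\c3ccc(O)c(O)c3)C2=O)cc1OC` differs from it as follows: hydroxy in place of hydrogen on an aromatic carbon. This places hydroxy in place of hydrogen on an aromatic carbon, turning 4-hydroxyphenyl into 3,4-dihydroxyphenyl. Within the data shown here, the only measured step, a 2.2-fold higher number from compound 1 to compound 2 (0.34 log units; beyond the scatter), is a different change, hydrogen in place of methyl on an oxygen, so it bears only indirectly. No shift beyond the scatter is therefore expected, and the estimated step is a 1.5-fold lower number from compound 2 to compound 3 (0.19 log units; within the scatter). For compound 3 the estimate is 11000 nM, with an expected range of 4000 nM to 28000 nM.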

Compound 3, half-maximal inhibitory concentration: 14400 nM
For compound 3 the middle estimate is 1.3-fold (0.12 log units) below the measured one; low and high end bracket the measured number.
By their numbers in this assay, from the lowest: compounds 1, 3 and 2 (each within the scatter of the next, the first and the last beyond it).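

On the aromatic carbon ortho to a hydroxy group, hydroxy in place of hydrogen leaves the number in this assay unchanged within the scatter (a 1.2-fold lower number from compound 2 to compound 3 (0.07 log units; within the scatter)). The 3,4-dihydroxyphenyl compound also lies within the scatter on the wider comparison (a 1.8-fold higher number from compound 1 to compound 3 (0.27 log units; within the scatter)), unlike the 4-hydroxyphenyl compound (a 2.2-fold higher number from compound 1 to compound 2 (0.34 log units; beyond the scatter)). No supporting data bear on this result.

Still open, as far as these compounds go, is whether an amine or a carboxylic acid on this same aromatic carbon would move the number beyond the scatter.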